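The source may report more compounds than this note shows. Statements on the series, on what has been measured and on what is new or still open speak of the compounds shown alone.

Compound 1 `CC(C)=CCC1Cc2c(OCc3ccccc3)cc(=O)n(CCCO)c2CC1(C)C`: -0.3%
Compound 2 `CC(C)=CCC1Cc2c(OCCCNS(=O)(=O)c3ccc(C(F)(F)F)cc3)cc(=O)n(CCCO)c2CC1(C)C`: 29.6%
Compound 3 `CC(C)=CCC1Cc2c(OCCCNC(=O)c3ccc([N+](=O)[O-])cc3)cc(=O)n(CCCO)c2CC1(C)C`: 49.9%

In a functional assay on PANC-1 cells (Homo sapiens) for inhibition, read by MTT assay, with a stated time of 24 h, tested at 10 uM (a lower number here means less inhibition, a higher number more inhibition at the concentration tested (going by the name of the read-out)), compound 1 stands lowest of the three numbers. Compound 2 lies higher by a gap beyond the usual scatter, and compound 3 higher still, also beyond it. Compound 4 `CC(C)=CCC1Cc2c(OC(=O)Nc3ccccc3F)cc(=O)n(CCCO)c2CC1(C)C` arises from compound 1 by a single change at the oxygen on the aromatic ring: (2-fluorophenyl)carbamoyl in place of benzyl on an oxygen on an aromatic ring. Within the data shown here, no measured pair shows this exact change, so its effect is not yet known. Compound 2 and compound 3 carry other replacements of the benzyl group on that same oxygen and both give more inhibition than compound 1. A moderate rise is therefore expected, a number 18.3 percentage points higher from compound 1 to compound 4 (beyond the scatter), though the new group resembles neither of those chains. For compound 4 an inhibition of 18% is estimated, with a range from -5% to 42%.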

Compound 4, a percentage reported as inhibition, at one concentration (the size of the read-out at that concentration, not a potency): 52.3%
The estimate for compound 4 lay 34.3 percentage points below the measured number; the measured number lies above the stated range.
By their numbers in this assay, from the lowest: compound 1; then compound 2; then compounds 3 and 4 (each within the scatter of the next).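

In this assay putting (2-fluorophenyl)carbamoyl in place of benzyl on an oxygen on an aromatic ring gives a number 52.6 percentage points higher from compound 1 to compound 4 (beyond the scatter) and shows that one change at this position can shift inhibition strongly. The rise does not require the chains carried there by compound 2 and compound 3, and compound 4 lies within the usual scatter of compound 3. Nothing available explains the size of this step.

Still open, on these data alone, is what the fluorine contributes, which a plain phenylcarbamoyl group on this oxygen would test. An acetyl group there would test whether the carbonyl link matters without the aromatic ring.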